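Working notes on compound 2 and compound 4

The source may hold more compounds than are shown below. What is called first, only, known or untested is meant among the compounds shown, and "the series" means these compounds.

The compounds share the core of compound 2 `Cc1ccc(/C=N/NC(=O)COc2cccc3ccccc23)cc1`. In an ADME assay on HEL cells (Homo sapiens) for cytotoxicity (a higher number here means that more compound is tolerated, a lower number that less compound is tolerated), compound 2 gives 20 ug/mL, the lowest of the two numbers measured. Compound 3 `C/C(=N\NC(=O)COc1cccc2ccccc12)c1ccc([N+](=O)[O-])cc1` gives 100 ug/mL in this assay, a higher number beyond the scatter. Compound 1 `COc1ccc(/C=N/NC(=O)COc2cccc3ccccc23)cc1OC` sits at the limit of >= 20 ug/mL in this assay, at which 1 of the 3 values shown sits, a limit rather than a number, recorded as >= 20 ug/mL. Compound 4 `O=C(COc1cccc2ccccc12)N/N=C/c1cccc(Br)c1` is not yet measured in this assay; it differs from compound 2 by 3-bromophenyl in place of 4-methylphenyl on a carbon with a double bond to nitrogen. Within the data shown here, no step between measured compounds is known for this kind of change. The expected step of a 1.3-fold higher number from compound 2 to compound 4 (0.10 log units; within the scatter) in this assay is therefore small, in no clear direction, and within the scatter. Compound 4 is expected to give 25 ug/mL, between 10 ug/mL and 60 ug/mL.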

Compound 4, minimum cytotoxic concentration: 100 ug/mL
Compound 4: middle estimate off by 4.0-fold (0.60 log units), on the low side; the measured number lies above the stated range.
By their numbers in this assay, from the lowest: compound 2; then compounds 3 and 4 (each within the scatter of the next).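

In this assay, 3-bromophenyl in place of 4-methylphenyl on a carbon with a double bond to nitrogen gives the first step readable at a single place in the series: a 5.0-fold higher number from compound 2 to compound 4 (0.70 log units; beyond the scatter). The number therefore responds to the group at this place, which no earlier comparison could show.

Going by these compounds, this single step changes the halogen and the ring position together, so it cannot separate them, and an amine or a carboxylic acid on the phenyl remains open. Compound 1 remains a limit, not a number, and gives no step: the limit of >= 20 ug/mL in this assay, at which 1 of the 4 values shown sits.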